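The source may report more compounds than this note shows. Statements on the series, on what has been measured and on what is new or still open speak of the compounds shown alone.

Working notes on the series built on the shared core of compound 1 `Cc1c(C(=O)CSCCNC(=O)c2ccc(F)cc2)[n+]([O-])c2ccccc2[n+]1[O-]` and compound 2 `COc1ccc(C(=O)NCCSCC(=O)c2c(C)[n+]([O-])c3ccccc3[n+]2[O-])cc1`, read in an ADME assay on Vero cells (Chlorocebus sabaeus) for cytotoxicity, read by MTT assay, with a stated time of 72 h; a lower number here means that less compound is tolerated, a higher number that more compound is tolerated. In this assay compound 1 gives only a limit, > 100 ug/mL. Compound 2 likewise reaches only a limit in this assay, > 100 ug/mL. Among the compounds with values here, the single measured step, a step that the two limits leave unreadable from compound 1 to compound 2, therefore cannot be sized, since both values sit at the limit of > 100 ug/mL in this assay, at which 2 of the 2 values shown sit. Compound 3 `Cc1c(C(=O)CSCCNC(=O)c2ccc3ccccc3c2)[n+]([O-])c2ccccc2[n+]1[O-]` carries the change (naphthalen-2-yl in place of 4-methoxyphenyl on a carbonyl carbon). Within the data shown here, no measured step resolves a number on either side of this change, so nothing argues for a reading beyond the scatter in this assay in either direction; the only bearing comes from the limit at which both earlier compounds rest. Compound 3 is expected to stay at that same limit, with the step that the limit leaves unreadable from compound 2 to compound 3 expected to be none beyond the scatter. The estimate for compound 3 in this assay is 150 ug/mL, with the range 70 ug/mL to 400 ug/mL.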

Compound 3, half-maximal cytotoxic concentration: > 100 ug/mL
Compound 3: a limit, no number (the forecaster's own chance of this, stated with the estimate: 80%); the middle value is on the limit's open side.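

No step from compound 1 or compound 2 to compound 3 can be read in this assay, since all three compounds rest on one limit: the limit of > 100 ug/mL in this assay, at which 3 of the 3 values shown sit.

The compounds shown leave open whether 4-fluorophenyl, 4-methoxyphenyl and naphthalen-2-yl differ at all in the concentration tolerated.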